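The source may report more compounds than this note shows. Statements on the series, on what has been measured and on what is new or still open speak of the compounds shown alone.

Going by the values given here, in a functional assay on M21 cells (Homo sapiens) for antiproliferative activity, read by sulforhodamine B assay, with a stated time of 48 h (a higher number here means a weaker inhibitor, a lower number a stronger inhibitor), compound 1 (`COc1ccccc1OS(=O)(=O)c1ccc(N2CCN(C)C2=O)cc1`) gives 21000 nM, the only true number in this short series. Compound 2 (`Cc1ccc(OS(=O)(=O)c2ccc(N3CCN(C)C3=O)cc2)cc1`) reads > 100000 nM, which is a limit of the assay. Compound 3 (`CCN1CCN(c2ccc(S(=O)(=O)Oc3ccccc3OC)cc2)C1=O`) reads > 100000 nM, also a limit and not a number. That puts it at the limit of > 100000 nM in this assay, at which 2 of the 3 values shown sit.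

Compound 4 (`CCN1CCN(c2ccc(S(=O)(=O)Oc3cccc(Br)c3)cc2)C1=O`) has 3-bromophenyl in place of 2-methoxyphenyl on an oxygen bound to the sulfonyl sulfur: 3-bromophenyl in place of 2-methoxyphenyl on an oxygen. Among the compounds with values here, no measured compound carries 3-bromophenyl, so its effect cannot be read directly.

The nearest measured change is an at least 4.7-fold higher number from compound 1 to compound 2 (0.67 log units; beyond the scatter), with 4-methylphenyl in place of 2-methoxyphenyl on that oxygen. The other is an at least 4.7-fold higher number from compound 1 to compound 3 (0.67 log units; beyond the scatter), with methyl in place of hydrogen on the chain, and this change is shared by compound 3 and compound 4. On these data alone, both steps are beyond the scatter, both raise the number, and both end at a limit, so their full size is unknown.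

Leaving 2-methoxyphenyl raised the number in the one case measured, and compound 4 also carries the chain of compound 3. Recovery of activity is therefore not expected in this assay. The expected step is an at least 1.2-fold lower number from compound 3 to compound 4 (0.09 log units; that floor lies within the scatter), which is none beyond the scatter. The estimated value for compound 4 is 80000 nM, with an expected range from 20000 nM to 200000 nM.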

Compound 4, half-maximal inhibitory concentration: 3400 nM
Compound 4: the middle estimate sits 24-fold (1.37 log units) above what was measured; measured number below the stated range.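

At the oxygen bound to the sulfonyl sulfur, leaving 2-methoxyphenyl does not always raise the number in this assay: 3-bromophenyl in its place gives an at least 29-fold lower number from compound 3 to compound 4 (1.46 log units; beyond the scatter). The earlier change at this oxygen, an at least 4.7-fold higher number from compound 1 to compound 2 (0.67 log units; beyond the scatter), ran the other way, so leaving 2-methoxyphenyl does not by itself fix the direction, and the chain of compound 3 does not rule out a low number once 3-bromophenyl is present. The reading for compound 3 is a limit of the assay and not a number, so the size of the new step is only a floor: the limit of > 100000 nM in this assay, at which 2 of the 4 values shown sit.

The compounds shown leave open whether 3-bromophenyl would have the same effect with the chain of compound 1, and 3-bromophenyl and 4-methylphenyl cannot be ranked directly, as their pairs carry different chains. On these data alone, it also remains open whether the bromine itself matters or whether another group on the phenyl ring, such as chlorine, an amine or a carboxylic acid, would give a similar number in this assay.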